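This account rests on a few compounds, and the source may have more. Where it says the series, first, only, none or still open, it means among the compounds named here.

Compound 1 `CC(O)CC#Cc1c(Cl)c2c(Cl)cc(C(N)=O)nc2n1[C@H]1CCCNC1` gives 48 nM in a functional assay on KG-1 cells (Homo sapiens) for antiproliferative activity (a lower number here means that less compound is needed, a higher number that more compound is needed for the effect), the lowest of the three numbers measured. Compound 2 `NC(=O)c1cc(Cl)c2c(Cl)c(C#CC3CCOCC3)n([C@H]3CCCNC3)c2n1` gives 69 nM, and compound 3 `CC1(C#Cc2c(Cl)c3c(Cl)cc(C(N)=O)nc3n2[C@H]2CCCNC2)COC1` gives 119 nM. The steps are a 1.4-fold higher number from compound 1 to compound 2 (0.16 log units; within the scatter) and a 2.5-fold higher number from compound 1 to compound 3 (0.39 log units; beyond the scatter); between these two, a 1.7-fold higher number from compound 2 to compound 3 (0.24 log units; within the scatter). Compound 4 `CC(C)(O)C#Cc1c(Cl)c2c(Cl)cc(C(N)=O)nc2n1[C@H]1CCCNC1` differs from compound 1 by 1-hydroxy-1-methylethyl in place of 2-hydroxypropyl on a triple-bonded carbon. All three measured steps vary the group on the triple-bonded carbon, and each moves the number upward only a little or within the scatter, so a step from compound 1 to compound 4 of the size a 1.3-fold higher number from compound 1 to compound 4 (0.10 log units; within the scatter) is expected, most likely within the scatter. Compound 4 is therefore estimated at 60 nM, with a range of 30 nM to 130 nM.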

Compound 4, half-maximal effective concentration: 302 nM
Estimate against measurement, compound 4: 5.0-fold (0.70 log units) below, and the stated range ends below it.
By their numbers in this assay, from the lowest: compounds 1, 2 and 3 (each within the scatter of the next, the first and the last beyond it); then compound 4.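

In this assay, rearranging the same atoms from 2-hydroxypropyl to 1-hydroxy-1-methylethyl gives a 6.3-fold higher number from compound 1 to compound 4 (0.80 log units; beyond the scatter), a larger step than any among the earlier groups on this triple-bonded carbon. The new group also compares poorly with the oxan-4-yl and 3-methyloxetan-3-yl groups, with a 4.4-fold higher number from compound 2 to compound 4 (0.64 log units; beyond the scatter) and a 2.5-fold higher number from compound 3 to compound 4 (0.40 log units; beyond the scatter), so carrying a hydroxyl does not alone keep the number low: compound 1 and compound 4 both carry one. Nothing available here explains the step. The compounds shown leave open whether an amine in place of that hydroxyl, or a longer chain bearing it, would behave alike.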